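This account rests on a few compounds, and the source may have more. Where it says the series, first, only, none or still open, it means among the compounds named here.

In an ADME assay on cells (Bos taurus) for cytotoxicity (a lower number here means that less compound is tolerated, a higher number that more compound is tolerated), compound 1 (`CSc1ccccc1SCO[C@H]1C[C@H](n2cnc3c(N)ncnc32)O[C@@H]1CO`) reads > 100000 nM, which is a limit and not a number. Compound 2 (`O=c1ccn([C@@H]2O[C@H](CO)C(OC3Sc4ccccc4S3)[C@@H]2O)c(=O)[nH]1`) gives 73900 nM and compound 3 (`O=c1ccn([C@@H]2O[C@H](CO)C(O)[C@@H]2OC2Sc3ccccc3S2)c(=O)[nH]1`) gives 67300 nM. These two values lie within the scatter of each other, so compound 3 stands level with compound 2. Compound 4 (`O=c1ccn([C@@H]2O[C@H](CO)C(OC3Sc4ccccc4S3)[C@@H]2OC2Sc3ccccc3S2)c(=O)[nH]1`) follows from compound 3 through (a group of 9 heavy atoms (7 carbon, 2 sulfur; one five-membered non-aromatic ring with 2 hetero atoms, one six-membered aromatic ring of carbon only) in place of a hydrogen atom, on an oxygen on a saturated carbon). The incoming group has one five-membered non-aromatic ring and one six-membered aromatic ring of carbon only. Among the compounds with values here, no measured pair shows the size of such a change, so only a modest fall in this assay is expected, estimated as a 1.5-fold lower number from compound 3 to compound 4 (0.17 log units; within the scatter). For compound 4 the estimated value is 45000 nM, with an expected range of 18000 nM to 100000 nM.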

Compound 4, half-maximal cytotoxic concentration: 48000 nM
Compound 4: the middle estimate sits 1.1-fold (0.03 log units) below what was measured; low and high end bracket the measured number.
By their numbers in this assay, from the lowest: compounds 4, 3 and 2 (each within the scatter of the next). At a limit, above all of these: compound 1.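

In this assay, a second group of this kind, on an oxygen on a saturated carbon, gives two steps that both stay within the scatter: a 1.4-fold lower number from compound 3 to compound 4 (0.15 log units; within the scatter) and a 1.5-fold lower number from compound 2 to compound 4 (0.19 log units; within the scatter). Within the data shown here, these are the first measured pairs, and neither step shows the added group moving the number beyond the scatter, whichever of the two starting compounds is used.

Compound 1 remains a limit and not a number: the limit of > 100000 nM in this assay, at which 1 of the 4 values shown sits.

Going by these compounds, whether a methyl group or an amine-bearing chain on that oxygen would also stay within the scatter remains open.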